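A few compounds are considered here, and "the series" means these few. Any claim that something is new, unique, unknown or untested is made for them only; others in the source may bear on it.

Measured compounds:
compound 1 `COc1cc2c(Oc3ccc(NC(=O)c4nccc(-c5ccc(F)cc5F)n4)cc3F)ccnc2cc1OCCCN1CCCCC1` — 780 nM
compound 2 `COc1cc2c(Oc3ccc(NC(=O)c4nccc(-c5ccc(F)cc5)n4)cc3F)ccnc2cc1OCCCN1CCN(C)CC1` — 910 nM

In a functional assay on U-87MG ATCC cells (Homo sapiens) for cytotoxicity, read by MTT assay, with a stated time of 72 h (a lower number here means a stronger inhibitor, a higher number a weaker inhibitor), compound 2 gives 910 nM, the higher of the two numbers measured, though compound 1 at 780 nM sits within the scatter of it, so the two are not separated. Compound 3 `COc1cc2c(Oc3ccc(NC(=O)c4nccc(-c5ccc(F)cc5F)n4)cc3F)ccnc2cc1OCCCN1CCN(C)CC1` carries fluoro in place of hydrogen on an aromatic carbon, which reads 4-fluorophenyl to 2,4-difluorophenyl. Within the data shown here, no comparable step between measured compounds exists here; compound 1 already holds the 2,4-difluorophenyl group with a different chain terminus and does not stand apart from compound 2. The step from compound 2 to compound 3 is therefore expected to be a 1.1-fold lower number from compound 2 to compound 3 (0.06 log units; within the scatter), nothing beyond the scatter. For compound 3 the estimate in this assay is 800 nM, ranging from 350 nM to 1800 nM.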

Compound 3, half-maximal inhibitory concentration: 780 nM
Estimate against measurement, compound 3: 1.0-fold (0.01 log units) above; measured number inside the range.
By their numbers in this assay, from the lowest: compounds 1, 3 and 2 (each within the scatter of the next).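

In this assay the change from 4-fluorophenyl to 2,4-difluorophenyl, with fluoro entering ortho to a large group, gives a 1.2-fold lower number from compound 2 to compound 3 (0.07 log units; within the scatter) and does not separate the two compounds. 4-Methylpiperazin-1-yl in place of piperidin-1-yl on the saturated chain, now read with the 2,4-difluorophenyl group held constant, gives no change at the digits printed from compound 1 to compound 3 (within the scatter) and does not separate these two chain termini either. No measurement shown here offers an explanation for either result. 

On these data alone, whether a chloro or methoxy group on this aromatic carbon, or a morpholine or longer chain at the chain terminus, would move the number beyond the scatter remains open.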